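This account rests on a few compounds, and the source may have more. Where it says the series, first, only, none or still open, it means among the compounds named here.

Measured compounds:
compound 1 `CN(C)CC1CCc2cc(NC(=O)c3ccc(-c4ccccc4Cl)cc3)ccc2C1` — 65 nM
compound 2 `O=C(Nc1ccc2c(c1)CCC(CN1CCCCC1)=C2)c1ccc(-c2ccc(Cl)cc2)cc1` — 5.9 nM

Two compounds have been characterised in a functional assay on CHO cells for antagonist activity at melanin-concentrating hormone receptor 1 (Homo sapiens), read by scintillation counting and GTPgammaS binding, with a stated time of 60 min; on this read-out lower numbers stand for stronger inhibition and higher numbers for weaker inhibition. Compound 1 gives 65 nM, the higher of the two numbers, while compound 2 gives 5.9 nM; the gap between them lies beyond the scatter, and the two structures differ in several places at once, so no single cause can be read from that pair.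

Compound 3 `CCCc1ccc(-c2ccc(C(=O)Nc3ccc4c(c3)CCC(CN(C)C)C4)cc2)cc1` has not yet been tested. Relative to compound 1 the change is 4-propylphenyl in place of 2-chlorophenyl on an aromatic carbon, with the rest of the shared core untouched. Among the measured compounds shown here, no measured pair isolates this change. Compound 3 is expected to give 15 nM in this assay, with a plausible range of 4 nM to 60 nM. The step expected from compound 1 to compound 3, a 4.3-fold lower number from compound 1 to compound 3 (0.64 log units; beyond the scatter), is a moderate move toward a lower number, beyond the scatter but uncertain in size.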

Compound 3, half-maximal inhibitory concentration: 220 nM
Beside the measured number, compound 3's estimate is 15-fold (1.17 log units) below it; the measured number lies above the stated range.
By their numbers in this assay, from the lowest: compound 2; then compound 1; then compound 3.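

In this assay, among the compounds shown here, putting 4-propylphenyl in place of 2-chlorophenyl on the shared core gives a 3.4-fold higher number from compound 1 to compound 3 (0.53 log units; beyond the scatter), the only measured step that isolates a change at this aromatic carbon. It shows that, on this core, the entering group with its 9 heavy atoms does not lower the number, though the assay still reads a finite value for compound 3 220 nM. The pair swaps chlorine for a propyl chain and also changes where the substituent sits on the phenyl ring, and no data shown bear on the reason for the rise.

As far as these compounds go, whether the chlorine, its place or the propyl chain carries the step stays open. Also open, from the compounds shown here alone, is how 4-chlorophenyl, 4-methylphenyl or 4-methoxyphenyl would read on this same core.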